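A few compounds are considered here, and "the series" means these few. Any claim that something is new, unique, unknown or untested is made for them only; others in the source may bear on it.

Of the compounds shown here, three built on one shared core have been measured so far. Compound 1 `O=C1c2ccccc2C(=O)N1CS` gives in a functional assay on PC-3 cells (Homo sapiens) for cytotoxicity, read by MTT assay, with a stated time of 72 h (a lower number here means a stronger inhibitor of growth, a higher number a weaker inhibitor of growth), only a limit of the assay, > 100000 nM. Compound 2 `O=C1c2ccccc2C(=O)N1C[SeH]` gives in this assay 9400 nM. Compound 3 `N#CSCN1C(=O)c2ccccc2C1=O` likewise gives in this assay only a limit, > 100000 nM. Among the numbers shown, compound 3 therefore stands at the weak end, resting at the point where two of the three values sit, with no number of its own (the limit of > 100000 nM in this assay, at which 2 of the 3 values shown sit).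

Compound 4 `N#C[Se]CN1C(=O)c2ccccc2C1=O` differs from compound 3 by a group of 3 heavy atoms (1 carbon, 1 nitrogen, 1 selenium; no ring) in place of a group of 3 heavy atoms (1 carbon, 1 nitrogen, 1 sulfur; no ring), on a saturated chain carbon bound to an amide-type nitrogen in a ring. For the measured compounds named here, one measured step bears directly on this exchange of a selenium atom for a sulfur atom on the same carbon: an at least 10-fold lower number from compound 1 to compound 2 (1.02 log units; beyond the scatter), a large drop. The step of an at least 10-fold higher number from compound 2 to compound 3 (1.02 log units; beyond the scatter) runs the other way when the selenium is given up for the cyanosulfanyl group, and the step that the two limits leave unreadable from compound 1 to compound 3 cannot be sized. Since compound 3 is known only as a limit, the true size of the coming step is uncertain, but a large drop in the number is expected, an at least 6.6-fold lower number from compound 3 to compound 4 (0.82 log units; beyond the scatter). Compound 4 is thus estimated at 15000 nM, with a range from 3000 nM to 100000 nM.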

Compound 4, concentration for total growth inhibition: 32100 nM
For compound 4 the middle estimate is 2.1-fold (0.33 log units) below the measured one; the measured number falls inside the stated range.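

In this assay, for the compounds shown here, the gain from selenium over sulfur, so far seen only in the pair carrying a bare hydrogen on the heteroatom, also appears when both atoms carry a nitrile (an at least 3.1-fold lower number from compound 3 to compound 4 (0.49 log units; beyond the scatter)). At the same position, cyano in place of hydrogen on the selenium raises the number only modestly (a 3.4-fold higher number from compound 2 to compound 4 (0.53 log units; beyond the scatter)), so compound 4 keeps a measurable value, whereas its sulfur counterpart, compound 3, does not. Compound 4 also separates from the first sulfur compound (an at least 3.1-fold lower number from compound 1 to compound 4 (0.49 log units; beyond the scatter)), but this step and the one from the nitrile-bearing sulfur compound both start from a limit, so their true sizes remain unknown, and the two sulfur compounds rest at the same point: the limit of > 100000 nM in this assay, at which 2 of the 4 values shown sit.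

The compounds shown leave open whether the selenium advantage survives on a longer chain, or with a methyl group or a carboxylic acid on the selenium in place of hydrogen or cyano. They also do not tell whether it would persist with a fluorine atom or an amine added to the shared core.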